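This account rests on a few compounds, and the source may have more. Where it says the series, first, only, none or still open, it means among the compounds named here.

In a functional assay on G-361 cells (Homo sapiens) for antiproliferative activity, with a stated time of 72 h (a higher number here means a weaker inhibitor, a lower number a stronger inhibitor), three compounds sharing one core have been tested so far, and none has yet given a number. Compound 1 `OC[C@H]1O[C@@H](n2cnc3c(NCc4cccc(F)c4)ncnc32)[C@H](O)[C@@H]1O` reads > 166000 nM, which is a limit. Compound 2 `COc1ccccc1CNc1ncnc2c1ncn2[C@@H]1O[C@H](CO)[C@@H](O)[C@H]1O` reads > 166000 nM, also a limit. Compound 3 `OC[C@H]1O[C@@H](n2cnc3c(NCc4ccc(F)cc4Cl)ncnc32)[C@H](O)[C@@H]1O` reads > 166000 nM, again a limit. Compound 3 therefore stands at the limit of > 166000 nM in this assay, at which 3 of the 3 values shown sit.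

Compound 4 `OC[C@H]1O[C@@H](n2cnc3c(NCc4ccccc4OC(F)F)ncnc32)[C@H](O)[C@@H]1O` keeps the core but carries 2-(difluoromethoxy)phenyl in place of 2-chloro-4-fluorophenyl on a saturated chain carbon bound to a nitrogen on an aromatic ring.

Three measured swaps at this same place bear on the change: a step that the two limits leave unreadable from compound 1 to compound 2, a step that the two limits leave unreadable from compound 1 to compound 3 and a step that the two limits leave unreadable from compound 2 to compound 3. None has a readable size, so they give no direction, but none of these three compounds produced a number in this assay. No shift beyond the usual scatter is therefore expected, and the expected change is a number no higher from compound 3 to compound 4 (the limit leaves the size open). Most likely the reading will again be only a limit. If a number does appear, compound 4 is estimated at 166000 nM, within an expected range of 50000 nM to 300000 nM.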

Compound 4, half-maximal inhibitory concentration: > 166000 nM
Compound 4 was reported as a limit; the forecaster's own chance of this, stated with the estimate: 85%; the middle value sits exactly at the limit.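

In this assay compound 4 gives only a limit, as do compound 1, compound 2 and compound 3, so none of the steps from those three compounds to compound 4 can be read. As far as these compounds go, whether any group on the shared core gives a readable number in this assay stays open.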